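Pyrrolidinyl cap in place of the thioether alkyl tail

The source may hold more compounds than are shown below. What is called first, only, known or untested is meant among the compounds shown, and "the series" means these compounds.

Measured compounds:
compound 1 `CCCCCSc1nc(C(C)(C)C)ccc1CNC(=O)C(C)c1ccc(NS(C)(=O)=O)c(F)c1` — 3.1 nM in an assay on cells for antagonist activity at transient receptor potential cation channel subfamily V member 1 (Homo sapiens), read by FLIPR and calcium flux, with a stated time of 6 min; a higher number here means a weaker inhibitor, a lower number a stronger inhibitor
compound 2 `CCCCCCSc1nc(C(C)(C)C)ccc1CNC(=O)C(C)c1ccc(NS(C)(=O)=O)c(F)c1` — 1.5 nM in this assay

Within the data shown here, compound 2 gives the lowest of the two numbers in this assay; its nearest neighbour is compound 1, and the single step between them, a 2.1-fold lower number from compound 1 to compound 2 (0.32 log units; beyond the scatter), shows that one more carbon on the thioether chain moved the number down modestly.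

Compound 3 `CC(C(=O)NCc1ccc(C(C)(C)C)nc1SCCCN1CCCC1)c1ccc(NS(C)(=O)=O)c(F)c1` differs from compound 2 in that chain: pyrrolidin-1-yl in place of propyl on a saturated chain carbon, three bonds along the chain from a sulfur. The change keeps the chain length counted in bonds from the sulfur but ends it in a five-membered non-aromatic ring with one hetero atom rather than in an open alkyl. Among the measured compounds shown here, no measured step involves a ring or a nitrogen on this chain, so the only step that bears on it is the chain-extension step from compound 1 to compound 2, and that step speaks only to added saturated carbon, not to the ring-with-nitrogen terminus introduced here.

For compound 3 the expectation in this assay is therefore a step near or somewhat above the scatter toward a higher number, a 2.7-fold higher number from compound 2 to compound 3 (0.43 log units; beyond the scatter), with an estimated value of 4 nM and a range from 1 nM to 15 nM.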

Compound 3, inhibition constant: 17.1 nM
Compound 3: the middle estimate sits 4.3-fold (0.63 log units) below what was measured, outside the stated range (above it).
By their numbers in this assay, from the lowest: compound 2; then compound 1; then compound 3.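

In this assay, ending the chain at this place in pyrrolidin-1-yl gives the largest step yet seen on the thioether tail: an 11-fold higher number from compound 2 to compound 3 (1.06 log units; beyond the scatter) against the hexyl chain, and a 5.5-fold higher number from compound 1 to compound 3 (0.74 log units; beyond the scatter) against the shorter pentyl chain. The position therefore responds to the identity of the chain end and not only to its length: the one alkyl extension, a 2.1-fold lower number from compound 1 to compound 2 (0.32 log units; beyond the scatter), went the other way and was much smaller, and compound 3 shows that this direction does not hold for every change to the tail. No measurement in hand speaks to the origin of the shift.

The compounds shown leave open whether the higher number goes with the ring or with the nitrogen, a question that a cyclopentyl group or an open dimethylamino group at the same place would separate. Also open, going by these compounds, are how the number responds to a longer or shorter chain between the sulfur and the pyrrolidin-1-yl group, and whether a heptyl chain would extend the small alkyl trend.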